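Naphthyl attachment change on the shared core

A few compounds are considered here, and "the series" means these few. Any claim that something is new, unique, unknown or untested is made for them only; others in the source may bear on it.

Measured compounds:
compound 1 `Clc1ccc(CO/N=C/c2c(-c3ccc4ccccc4c3)nc3sccn23)cc1Cl` 380 nM
compound 2 `Fc1c(F)c(F)c(CO/N=C/c2c(-c3ccc4ccccc4c3)nc3occn23)c(F)c1F` 1700 nM
compound 3 `Clc1ccc(CO/N=C/c2c(-c3ccc4ccccc4c3)nc3occn23)cc1Cl` 370 nM

In an assay on HepG2 cells for agonist activity at nuclear receptor subfamily 1 group I member 3 (Homo sapiens), read by a luciferase reporter, with a stated time of 23 h (on this read-out higher numbers stand for an effect only at larger amounts of compound and lower numbers for an effect already at smaller amounts), compound 1 gives 380 nM and stands second highest of the three numbers. Its nearest neighbour is compound 3, whose value of 370 nM lies within the scatter of compound 1, so no order can be read between them. The furthest is compound 2 at 1700 nM, beyond the scatter from compound 1.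

Among the measured compounds shown here, the only measured step is a 4.6-fold lower number from compound 2 to compound 3 (0.66 log units; beyond the scatter). It changes the group on the saturated chain carbon bound to the oxygen, not the group on the core, so it does not bear on the change considered here.

Compound 4 `Clc1ccc(CO/N=C/c2c(-c3cccc4ccccc34)nc3sccn23)cc1Cl` is not yet measured. It differs from compound 1 in that (naphthalen-1-yl in place of naphthalen-2-yl on an aromatic carbon). For the measured compounds named here, no measured pair addresses this change, and the values of compound 1 and compound 3 show only that the single-atom difference in the shared core stays within the scatter.

Compound 4 is therefore expected near compound 1, with a 1.3-fold higher number from compound 1 to compound 4 (0.12 log units; within the scatter) anticipated as a step not beyond the scatter. Compound 4 is estimated at 500 nM, within a range of 180 nM to 1500 nM.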

Compound 4, half-maximal effective concentration: 940 nM
For compound 4 the middle estimate is 1.9-fold (0.27 log units) below the measured one; low and high end bracket the measured number.
By their numbers in this assay, from the lowest: compounds 3 and 1 (each within the scatter of the next); then compounds 4 and 2 (each within the scatter of the next).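

In this assay, among the compounds shown here, the switch to naphthalen-1-yl from naphthalen-2-yl gives a 2.5-fold higher number from compound 1 to compound 4 (0.39 log units; beyond the scatter) and is the first measured step at this position, the aromatic carbon of the five-membered aromatic ring with 2 nitrogen. The two groups match in atoms and in their counts of rings, donors and acceptors and differ only in how they are joined, so the attachment point of the naphthalene alone is enough to shift the number beyond the scatter, with naphthalen-2-yl giving the lower number in this single pair. No measured property accompanies this step, and the data offer no explanation for it.

Going by these compounds, this reading rests on one pair on the core of compound 1, and whether the same switch gives a step of like size on the core of compound 3 stays open. Also open, on these data alone, is how this position reads with a plain phenyl ring, an amine or a carboxylic acid in place of the naphthalene.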